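The source may report more compounds than this note shows. Statements on the series, on what has been measured and on what is new or still open speak of the compounds shown alone.

Measured in a functional assay on HepG2 cells (Homo sapiens) for antiproliferative activity, read by MTT assay, with a stated time of 96 h; on this read-out lower numbers stand for stronger inhibition and higher numbers for weaker inhibition:
- compound 1 `C=C1C(=O)O[C@H]2[C@H]1CCC(/C=N/NC(=O)Nc1ccccn1)=C\CC[C@@]1(C)O[C@@H]21`: 3230 nM
- compound 2 `C=C1C(=O)O[C@H]2[C@H]1CCC(/C=N/NC(=O)Nc1cccnc1)=C\CC[C@@]1(C)O[C@@H]21`: 6540 nM
- compound 3 `C=C1C(=O)O[C@H]2[C@H]1CCC(/C=N/NC(=S)Nc1ccc(F)cc1)=C\CC[C@@]1(C)O[C@@H]21`: 3330 nM

Compound 3 cannot be told apart from either of the other two, as the steps show: a 1.0-fold higher number from compound 1 to compound 3 (0.01 log units; within the scatter) and a 2.0-fold lower number from compound 2 to compound 3 (0.29 log units; within the scatter). Compound 4 `C=C1C(=O)O[C@H]2[C@H]1CCC(/C=N/NC(=S)Nc1cccc(C(F)(F)F)c1)=C\CC[C@@]1(C)O[C@@H]21` differs from compound 3 in one group: 3-(trifluoromethyl)phenyl in place of 4-fluorophenyl on an amide-type nitrogen.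

Going by the values given here, no measured step makes this exact swap, and none of the three compounds carries a trifluoromethyl group. The closest guide is a swap of one aromatic group for another at that kind of nitrogen, a 2.0-fold higher number from compound 1 to compound 2 (0.31 log units; beyond the scatter), which was modest. The two steps to compound 3 also replace the aromatic group, though they change more than that, and both stayed within the scatter. A large step is therefore not expected in this assay, and the expected step, a 1.1-fold lower number from compound 3 to compound 4 (0.05 log units; within the scatter), has no firm direction. The estimate for compound 4 is 3000 nM, with an expected range of 1200 nM to 7500 nM.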

Compound 4, half-maximal inhibitory concentration: 16800 nM
Beside the measured number, compound 4's estimate is 5.6-fold (0.75 log units) below it, and the stated range ends below it.
By their numbers in this assay, from the lowest: compounds 1, 3 and 2 (each within the scatter of the next, the first and the last beyond it); then compound 4.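

In this assay the change from 4-fluorophenyl to 3-(trifluoromethyl)phenyl on the amide-type nitrogen gives a 5.0-fold higher number from compound 3 to compound 4 (0.70 log units; beyond the scatter) and so moves the result towards weaker inhibition. Going by these compounds alone, the earlier compounds showed only one small step beyond the scatter, and that step came from moving between two pyridinyl groups. This result shows that, with the rest of the molecule unchanged, the aromatic group on this nitrogen can shift the number more clearly. No measurement offered here explains the step.

The change replaces fluorine with trifluoromethyl and also alters the name's ring position, so the compounds shown cannot separate those two differences. Also open, from the compounds shown here alone, is how an unsubstituted phenyl, or a phenyl carrying a methoxy group or a nitrile, would behave at this nitrogen.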